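A few compounds are considered here, and "the series" means these few. Any claim that something is new, unique, unknown or untested is made for them only; others in the source may bear on it.

Compound 1 `CN(C)CCn1cnnc1-c1cc(Oc2ccc(NC(=O)N/N=C/c3ccc(O)cc3)cc2F)ccn1`: 1780 nM
Compound 2 `COc1ccc(/C=N/NC(=O)Nc2ccc(Oc3ccnc(-c4nncn4CCN(C)C)c3)c(F)c2)cc1O`: 620 nM
Compound 3 `CN(C)CCn1cnnc1-c1cc(Oc2ccc(NC(=O)N/N=C/c3c(Cl)cccc3Cl)cc2F)ccn1`: 350 nM

The three share one core and differ only in the aryl group on a carbon with a double bond to nitrogen, all read in a functional assay on NCI-H460 cells (Homo sapiens) for cytotoxicity, read by MTT assay, with a stated time of 72 h; on this read-out higher numbers stand for weaker inhibition and lower numbers for stronger inhibition. Compound 3 gives the lowest number of the three: the step of a 1.8-fold lower number from compound 2 to compound 3 (0.25 log units; within the scatter) is within the scatter, while a 5.1-fold lower number from compound 1 to compound 3 (0.71 log units; beyond the scatter) is beyond it. Compound 4 `CN(C)CCn1cnnc1-c1cc(Oc2ccc(NC(=O)N/N=C/c3ccccc3)cc2F)ccn1` carries phenyl in place of 2,6-dichlorophenyl on a carbon with a double bond to nitrogen. Both measured steps into compound 3 move toward the dichloro ring and lower the number; the change to compound 4 runs the other way, so a modestly higher number is expected. For the measured compounds named here, no measured compound carries the bare ring, and the range is set wide. Compound 4 is estimated at 800 nM (range 350 nM to 2000 nM), an expected step of a 2.3-fold higher number from compound 3 to compound 4 (0.36 log units; beyond the scatter).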

Compound 4, half-maximal inhibitory concentration: 1780 nM
Estimate against measurement, compound 4: 2.2-fold (0.35 log units) below, within the range that was stated.
By their numbers in this assay, from the lowest: compounds 3 and 2 (each within the scatter of the next); then compounds 1 and 4 (each within the scatter of the next).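

Hydrogen in place of hydroxy gives no change at the digits printed from compound 1 to compound 4 (within the scatter), so the bare phenyl ring and the 4-hydroxyphenyl ring read alike at this position. Phenyl in place of 2,6-dichlorophenyl gives a 5.1-fold higher number from compound 3 to compound 4 (0.71 log units; beyond the scatter), and phenyl in place of 3-hydroxy-4-methoxyphenyl gives a 2.9-fold higher number from compound 2 to compound 4 (0.46 log units; beyond the scatter), so the lower numbers of compound 3 and compound 2 go with the substituents on their rings, not with the aryl ring itself. Nothing measured here explains these steps.

As far as these compounds go, whether a single chlorine accounts for part of the step to compound 3, and whether the hydroxy or the methoxy matters more in compound 2, remains open. An amine or a carboxylic acid on this ring also remains untested in the compounds shown.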